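The source may report more compounds than this note shows. Statements on the series, on what has been measured and on what is new or still open speak of the compounds shown alone.

Compound 1 `COc1ccc(C(=O)ON=C2CC(c3ccc(O)c(OC)c3)N(C)C(c3ccc(O)c(OC)c3)C2)c(OC)c1` is an oxime ester whose acyl group is varied across the small set measured in a functional assay, read by spectrophotometry, with a stated time of 30 min (on this read-out lower numbers stand for stronger inhibition and higher numbers for weaker inhibition), where compound 1 gives 41000 nM. Its number is the second highest of the three; the nearest neighbour is compound 2 `COc1cc(C2CC(=NOC(=O)c3ccccc3O)CC(c3ccc(O)c(OC)c3)N2C)ccc1O`, which gives 15900 nM, and the furthest is compound 3 `COc1cc(C2CC(=NOC(=O)c3ccc(F)cc3)CC(c3ccc(O)c(OC)c3)N2C)ccc1O`, which gives 141000 nM. The measured steps are a 2.6-fold lower number from compound 1 to compound 2 (0.41 log units; beyond the scatter), a 3.4-fold higher number from compound 1 to compound 3 (0.54 log units; beyond the scatter) and an 8.9-fold higher number from compound 2 to compound 3 (0.95 log units; beyond the scatter), all of which exchange one aryl group for another on the carbonyl carbon and all of which are modest.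

Compound 4 `COc1cc(C2CC(=NO)CC(c3ccc(O)c(OC)c3)N2C)ccc1O` differs from compound 1 by hydrogen in place of (2,4-dimethoxyphenyl)carbonyl on an oxygen, so the whole acyl group is gone and a free oxime remains. For the measured compounds named here, no measured step removes the acyl group, so the three steps bear on it only indirectly: they show that changing the aryl on the carbonyl moves the number in this assay within a narrow band in either direction. Compound 4 is therefore expected to stay close to compound 1, with a step of a 1.2-fold higher number from compound 1 to compound 4 (0.09 log units; within the scatter) and an estimated value of 50000 nM, in the range 15000 nM to 160000 nM.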

Compound 4, half-maximal inhibitory concentration: 158000 nM
Compound 4: middle estimate off by 3.2-fold (0.50 log units), on the low side; the measured number falls inside the stated range.
By their numbers in this assay, from the lowest: compound 2; then compound 1; then compounds 3 and 4 (each within the scatter of the next).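

Removing the acyl group altogether is now measured directly, and in this assay the free oxime loses ground against two of the esters, with a 3.9-fold higher number from compound 1 to compound 4 (0.59 log units; beyond the scatter) and a 9.9-fold higher number from compound 2 to compound 4 (1.00 log units; beyond the scatter) for the 2,4-dimethoxyphenyl and 2-hydroxyphenyl cases. The acyl group does not lower the number in every case, as compound 3 goes against this pattern: with (4-fluorophenyl)carbonyl leaving, the result is a 1.1-fold higher number from compound 3 to compound 4 (0.05 log units; within the scatter) and the ester and the free oxime cannot be told apart. Nothing available explains why these acyl groups differ from one another at this oxygen.

On these data alone, it remains open how a small acetyl group, with no aromatic ring, would compare with the free oxime on this oxygen. A methyl group or a longer chain bearing an amine at the same place is also left open.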